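The source may report more compounds than this note shows. Statements on the series, on what has been measured and on what is new or still open speak of the compounds shown alone.

In a physicochemical assay for lipophilicity, using the shake flask method, in phosphate buffer, with a stated time of 1 h (a higher number here means a more lipophilic compound, a lower number a more polar compound), compound 1 `CC(C)(C)C(=O)OC[C@H]1O[C@@H](n2cnc3c(N)ncnc32)[C@@H](O)[C@@H]1O` gives 1.63, and compound 3 `CC(C)(C)CC(=O)OC[C@H]1O[C@@H](n2cnc3c(N)ncnc32)[C@@H](O)[C@@H]1O` gives 1.7, so the two sit level. Compound 2 `CCCCCCCC(=O)OC[C@H]1O[C@@H](n2cnc3c(N)ncnc32)[C@@H](O)[C@@H]1O` is reported only as a limit, >= 2. Its heptyl chain gives two steps with a floor rather than a fixed size: a number at least 0.37 log units higher from compound 1 to compound 2 (beyond the scatter), and a number at least 0.30 log units lower from compound 2 to compound 3 (that floor lies within the scatter).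

Compound 4 `CCCCC(=O)OC[C@H]1O[C@@H](n2cnc3c(N)ncnc32)[C@@H](O)[C@@H]1O` has propyl in place of tert-butyl on a saturated chain carbon bound to a carbonyl carbon. That turns neopentyl into butyl. Butyl stands nearer to neopentyl than to heptyl, and the one fully measured step, a number 0.07 log units higher from compound 1 to compound 3 (within the scatter), was small, so no step beyond the scatter is expected in this assay. The expected change is a number 0.10 log units lower from compound 3 to compound 4 (within the scatter). Compound 4 is estimated at 1.6, with an expected range of 1.3 to 1.9.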

Compound 4, partition coefficient: 1.33
Estimate against measurement, compound 4: 0.27 log units above; low and high end bracket the measured number.
By their numbers in this assay, from the lowest: compounds 4, 1 and 3 (each within the scatter of the next, the first and the last beyond it). At a limit, above all of these: compound 2.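

In this assay, among these compounds, propyl in place of tert-butyl on a saturated chain carbon bound to a carbonyl carbon gives the first fully measured step beyond the scatter: a number 0.37 log units lower from compound 3 to compound 4 (beyond the scatter). The other new step measured in full, by contrast, stays inside it: a number 0.30 log units lower from compound 1 to compound 4 (within the scatter). The step from the heptyl ester is only a floor, a number at least 0.67 log units lower from compound 2 to compound 4 (beyond the scatter), and compound 2 is reported as a limit: the limit of >= 2 in this assay, at which 1 of the 4 values shown sits.

Still open, on these data alone, is where a pentyl chain would fall in this assay, and how a chain ending in an amine or a carboxylic acid would read.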